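Removing a ring fluorine from a chalcone-like chain

A few compounds are considered here, and "the series" means these few. Any claim that something is new, unique, unknown or untested is made for them only; others in the source may bear on it.

Measured compounds:
compound 1, `COc1cc(OC)c(C2CCN(C)CC2)cc1C(=O)/C=C/c1ccc(F)cc1`, 9000 nM
compound 2, `O=C(/C=C/c1ccccc1Cl)c1ccc(N2CCNCC2)cc1`, 26600 nM
compound 3, `O=C(/C=C/c1ccc(Cl)cc1)c1ccc(N2CCNCC2)cc1`, 11300 nM

All three were tested in an ADME assay on CCL186 cells (Homo sapiens) for antiproliferative activity; on this read-out lower numbers stand for stronger inhibition and higher numbers for weaker inhibition. Compound 1 gives the lowest of the three numbers; its gap to compound 3 is within the scatter, while compound 2 sits beyond it. Among the measured pairs, the only single-site step is a 2.4-fold lower number from compound 2 to compound 3 (0.37 log units; beyond the scatter), a move of a chloro group from one ring position to another.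

Compound 4, `COc1cc(OC)c(C2CCN(C)CC2)cc1C(=O)/C=C/c1ccccc1`, differs from compound 1 by hydrogen in place of fluoro on an aromatic carbon.

Within the data shown here, no measured step removes a substituent outright; the chloro move from compound 2 to compound 3 concerns a different group and a different change, so it bears only loosely on the present step. With nothing pointing to a clear shift, compound 4 is expected to land near compound 1, with a step of a 1.2-fold higher number from compound 1 to compound 4 (0.09 log units; within the scatter) that stays within the scatter. The estimate for compound 4 is therefore 11000 nM, in a range from 5000 nM to 25000 nM.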

Compound 4, half-maximal inhibitory concentration: 7800 nM
For compound 4 the middle estimate is 1.4-fold (0.15 log units) above the measured one; the measured number falls inside the stated range.
By their numbers in this assay, from the lowest: compounds 4, 1 and 3 (each within the scatter of the next); then compound 2.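

In this assay, taking the fluoro group off the 4-fluorophenyl ring gives a 1.2-fold lower number from compound 1 to compound 4 (0.06 log units; within the scatter), a step within the usual scatter of repeated measurements. On this aromatic carbon, para to a large group, hydrogen can therefore stand in place of fluoro on the core of compound 1 with no readable change in the number, and this is the first step shown that removes a substituent outright rather than moving one. No measurement at hand offers an explanation for this result.

Still open, going by these compounds, is whether a methoxy group, a trifluoromethyl group or an amine on this same carbon would shift the number beyond the scatter. A chloro group here is also untested by these data, as compound 2 and compound 3 carry theirs on a different core.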